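The source may report more compounds than this note shows. Statements on the series, on what has been measured and on what is new or still open speak of the compounds shown alone.

Compound 1 `CC1(C)C(=O)Nc2ccc(OCc3ccc(F)cc3)cc21` carries a shared core with a 4-fluorophenyl group on the benzylic carbon. In an assay on cells for inhibition of Amine oxidase [flavin-containing] A (Homo sapiens), read by fluorescence, with stated times of 30 min and 15 min (a higher number here means a weaker inhibitor, a lower number a stronger inhibitor), compound 1 gives "not determined" (no result reported), so no number places it. Compound 2 `CCn1c(=O)[nH]c2ccc(OCc3ccc(C(F)(F)F)cc3)cc21` is the only measured relative. In this assay, going by the values given here, compound 2 reaches only a limit of the assay, > 500000 nM, and that is the single value shown (the limit of > 500000 nM in this assay, at which 1 of the 2 values shown sits). Compound 3 `CC1(C)C(=O)Nc2ccc(OCc3cccc(Cl)c3)cc21` differs from compound 1 by 3-chlorophenyl in place of 4-fluorophenyl on a saturated chain carbon bound to an oxygen on an aromatic ring. Among the compounds with values here, with no measured step to lean on, no shift beyond scatter can be predicted in this assay. For compound 3 the estimated value in this assay is 100000 nM, expected to lie between 5000 nM and 500000 nM.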

Compound 3, half-maximal inhibitory concentration: > 500000 nM
Compound 3 was reported as a limit; the forecaster's own chance of this, stated with the estimate: 50%; middle value at least 5.0-fold (0.69 log units) away from the limit.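

In this assay, going by these compounds alone, compound 3 gives > 500000 nM, which is a limit of the assay, and compound 1 has no number, so no step between the two can be read. The compounds shown leave open whether 3-chlorophenyl in place of 4-fluorophenyl changes inhibition at all.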